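Swapping a para substituent on the triazole-linked phenyl ring

A few compounds are considered here, and "the series" means these few. Any claim that something is new, unique, unknown or untested is made for them only; others in the source may bear on it.

Measured so far:
- compound 1 `N#CC1=C(N)Oc2c(c3nc4ccccc4nc3c3ccccc23)C12C(=O)N(Cc1cnnn1-c1ccccc1Cl)c1ccccc12`: 42600 nM
- compound 2 `CCOc1ccc(-n2nncc2CN2C(=O)C3(C(C#N)=C(N)Oc4c3c3nc5ccccc5nc3c3ccccc43)c3ccccc32)cc1`: 25200 nM

Both compounds were tested in a functional assay on A549 cells (Homo sapiens) for antiproliferative activity, read by MTT assay, with a stated time of 48 h; on this read-out lower numbers stand for stronger inhibition and higher numbers for weaker inhibition. Compound 1 gives 42600 nM, and compound 2 gives 25200 nM. For the measured compounds named here, the only comparison available between them, a 1.7-fold lower number from compound 1 to compound 2 (0.23 log units; within the scatter), comes from 4-ethoxyphenyl in place of 2-chlorophenyl on an aromatic nitrogen. Compound 2 therefore holds the lowest of the two numbers, but only by a margin that ordinary repeat measurements could erase, so neither compound can be called the more active one.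

Compound 3 `N#CC1=C(N)Oc2c(c3nc4ccccc4nc3c3ccccc23)C12C(=O)N(Cc1cnnn1-c1ccc(S(N)(=O)=O)cc1)c1ccccc12` is the next step from compound 2, with sulfamoyl in place of ethoxy on an aromatic carbon, a sulfamoyl in place of ethoxy on an aromatic carbon. Going by the values given here, no measured pair shows this particular exchange, and the one step that exists, from compound 1 to compound 2, stayed within the scatter. Nothing here points to a step beyond the scatter in this assay in either direction. Compound 3 is therefore expected to give about 30000 nM, within 10000 nM to 90000 nM, which means an expected step of a 1.2-fold higher number from compound 2 to compound 3 (0.08 log units; within the scatter).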

Compound 3, half-maximal inhibitory concentration: > 50000 nM
Compound 3 gave a limit, no number; the forecaster's own chance of this, stated with the estimate: 15%; middle value at least 1.6-fold (0.22 log units) away from the limit.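

The result for compound 3 in this assay is a limit of the assay and not a number: the limit of > 50000 nM in this assay, at which 1 of the 3 values shown sits. Putting sulfamoyl in place of ethoxy on the aromatic carbon para to a large group gives an at least 1.9-fold higher number from compound 2 to compound 3 (0.29 log units; that floor lies within the scatter), and the comparison with the 2-chlorophenyl compound gives an at least 1.1-fold higher number from compound 1 to compound 3 (0.06 log units; that floor lies within the scatter); each is only a floor, so the real gap could be small or considerably larger. For the compounds shown here, what this adds is that sulfamoyl, the only group here that carries a hydrogen-bond donor, gives no sign of a lower number at this position, whereas the earlier pair offered only two groups with no readable gap between them.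

The compounds shown leave open where the real number for compound 3 lies, and whether any group on this ring can move the result beyond the scatter in either direction. An amine or a carboxylic acid on the same aromatic carbon, or a butoxy chain in place of ethoxy, would show whether the outcome follows the sulfamoyl group in particular or holds for other groups at this position.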